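A Larger Ester Tail on the Strongest Inhibitor

A few compounds are considered here, and "the series" means these few. Any claim that something is new, unique, unknown or untested is made for them only; others in the source may bear on it.

Of the compounds shown here, three have so far been tested in a functional assay on HEK293 cells for antagonist activity at Voltage-dependent L-type calcium channel subunit alpha-1C (Oryctolagus cuniculus), read by FLIPR; a lower number here means a stronger inhibitor, a higher number a weaker inhibitor. Compound 2 `COC(=O)C1=C(C)NC(C)=C(C(=O)OCC(F)(F)F)C1c1cccc([N+](=O)[O-])c1` gives 16 nM and is the strongest inhibitor of the three: compound 3 `CCOC(=O)C1=C(C)NC(C)=C(C(=O)OCc2ccc([N+](=O)[O-])cc2)C1c1cccc([N+](=O)[O-])c1` gives 130 nM and compound 1 `CCOC(=O)C1=C(C)NC(CN2CCN(c3ccccc3)CC2)=C(C(=O)OCC)C1c1cccc([N+](=O)[O-])c1` gives 630 nM, with both gaps lying beyond the usual scatter. Compound 1 and compound 3 each differ from compound 2 in more than one place, so only their values can be set beside it.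

Compound 4 `COC(=O)C1=C(C)NC(C)=C(C(=O)OCCOCc2ccccc2)C1c1cccc([N+](=O)[O-])c1` has not yet been measured in this assay. It differs from compound 2 in one place: (benzyloxy)methyl in place of trifluoromethyl on a saturated chain carbon bound to an oxygen next to a carbonyl group. The entering group is the larger of the two and brings one ring and one hydrogen-bond acceptor. Within the data shown here, no single-change step between measured compounds is available to calibrate this swap, so the size of its effect is uncertain. The weaker numbers of compound 3 at 130 nM and compound 1 at 630 nM suggest that the other groups tried alongside the shared core gave up some potency. A moderate weakening is therefore expected, a 3.1-fold higher number from compound 2 to compound 4 (0.49 log units; beyond the scatter). Compound 4 is estimated at 50 nM, within 15 nM to 200 nM.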

Compound 4, half-maximal inhibitory concentration: 9 nM
Estimate against measurement, compound 4: 5.6-fold (0.74 log units) above; the whole stated range lies above it.
By their numbers in this assay, from the lowest: compounds 4 and 2 (each within the scatter of the next); then compound 3; then compound 1.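

In this assay, putting (benzyloxy)methyl in place of trifluoromethyl gives a 1.8-fold lower number from compound 2 to compound 4 (0.25 log units; within the scatter) and so leaves the two compounds indistinguishable. The earlier compounds shown here could not show this, as none of them differed in only one place: on a saturated chain carbon bound to an oxygen next to a carbonyl group, a group of 9 heavy atoms with a six-membered aromatic ring can replace one of 4 heavy atoms with no ring and inhibition stays in the same range. Nothing measured here explains why the swap leaves the number within the scatter.

From the compounds shown here alone, it remains open whether the ring or the chain oxygen matters more, which a simple 2-phenylethyl tail would help to separate. How a tail ending in an amine or a carboxylic acid would compare at this position is also unknown.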